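This account rests on a few compounds, and the source may have more. Where it says the series, first, only, none or still open, it means among the compounds named here.

Measured compounds:
compound 1, `O=C(Nc1ccc(NCc2ccc(F)cc2)cc1Cl)c1cc(Cl)ccc1O`, 54400 nM
compound 2, `O=C(Nc1ccc(NCc2ccc(C(F)(F)F)cc2)cc1Cl)c1cc(Cl)ccc1O`, 62700 nM
compound 3, `O=C(Nc1ccc(NCc2cc(F)cc(C(F)(F)F)c2)cc1Cl)c1cc(Cl)ccc1O`, 30900 nM

Of the compounds shown here, three have been tested in an ADME assay on A549 cells (Homo sapiens) for cytotoxicity, read by resazurin assay, with a stated time of 48 h; a higher number here means that more compound is tolerated, a lower number that less compound is tolerated. Compound 1 gives 54400 nM, compound 2 gives 62700 nM, and compound 3 gives 30900 nM. From compound 1 to compound 2 the change is trifluoromethyl in place of fluoro on an aromatic carbon, and it gave a 1.2-fold higher number from compound 1 to compound 2 (0.06 log units; within the scatter). Compound 4, `O=C(Nc1ccc(NCc2cc(C(F)(F)F)cc(C(F)(F)F)c2)cc1Cl)c1cc(Cl)ccc1O`, remains to be measured; it is made from compound 3 by trifluoromethyl in place of fluoro on an aromatic carbon. This is the same kind of change as that from compound 1 to compound 2, though the place differs: in compound 1 the fluoro sits para to a large group, whereas in compound 3 it sits meta to a large group and meta to a trifluoromethyl group. The difference between the two cores of compound 1 and compound 3 is not broken down here. Because the earlier step of a 1.2-fold higher number from compound 1 to compound 2 (0.06 log units; within the scatter) stayed within the scatter, compound 4 is expected to show a step of about a 1.1-fold higher number from compound 3 to compound 4 (0.05 log units; within the scatter) in this assay. Compound 4 is thus estimated at 35000 nM, within 15000 nM to 80000 nM.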

Compound 4, half-maximal cytotoxic concentration: 92800 nM
Estimate against measurement, compound 4: 2.7-fold (0.42 log units) below; measured number outside the range, above it.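

In this assay, trifluoromethyl in place of fluoro on an aromatic carbon gave a 3.0-fold higher number from compound 3 to compound 4 (0.48 log units; beyond the scatter), a step that on its own lies beyond the usual scatter. Set beside the earlier step on the other core, however, the new step cannot be told apart from it: the same change on two cores in this assay, a 1.2-fold higher number (0.06 log units; within the scatter) from compound 1 to compound 2 and a 3.0-fold higher number (0.48 log units; beyond the scatter) from compound 3 to compound 4, 2.6-fold (0.42 log units) apart, within the scatter of two such steps. These two pairs therefore do not show that the size of this step depends on the core, nor do they show that it stays the same across the series, so the change can be carried from one core to the other only with that uncertainty.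

The compounds shown carry only fluoro and trifluoromethyl on this aromatic ring, which leaves open how a nitrile, a methoxy group or an amine at the same place would read in this assay. Going by these compounds, it also remains open how the same change would behave on a third core, or in a compound bearing a carboxylic acid.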